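Carboxy in Place of Trifluoromethyl: Notes on Four Compounds

The source may report more compounds than this note shows. Statements on the series, on what has been measured and on what is new or still open speak of the compounds shown alone.

Measured so far in an assay on isolated protein for inhibition of 2-Hydroxyacid oxidase 2 (Homo sapiens), tested at 1 uM; a higher number here means a stronger effect of the compound at the concentration tested, a lower number a weaker effect:
compound 1 `Cc1n[nH]c(C(=O)O)c1Cc1cccc(C(F)(F)F)c1` gives 5%
compound 2 `Cc1n[nH]c(C(=O)O)c1Cc1cccc(-c2ccc(C(F)(F)F)cc2)c1` gives 8%
compound 3 `Cc1n[nH]c(C(=O)O)c1Cc1cccc(-c2ccc(C(=O)O)cc2)c1` gives 3%

All three numbers sit close together, and the gaps among them fall within the usual scatter, so no order is read into them. Compound 4 `Cc1n[nH]c(C(=O)O)c1Cc1cccc(C(=O)O)c1` has not been measured in this assay. It differs from compound 1 by carboxy in place of trifluoromethyl on an aromatic carbon. The same kind of change has been made once already, from compound 2 to compound 3, where it is carboxy in place of trifluoromethyl on an aromatic carbon and produced a number 5 percentage points lower from compound 2 to compound 3 (within the scatter). The two places are not the same word for word: in compound 1 the change is made meta to a large group, in compound 2 para to a large group. How the core of compound 1 differs from the core of compound 2 is not broken down here.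

Resting on the earlier step of a number 5 percentage points lower from compound 2 to compound 3 (within the scatter), a step of similar small size, a number 3 percentage points lower from compound 1 to compound 4 (within the scatter), is expected from compound 1 to compound 4. For compound 4 in this assay an inhibition of about 2% is estimated, between -8% and 12%.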

Compound 4, a percentage reported as inhibition, at one concentration (the size of the read-out at that concentration, not a potency): 3%
The estimate for compound 4 lay 1 percentage points below the measured number, and the stated range covers the measured number.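

In this assay, carboxy in place of trifluoromethyl on an aromatic carbon gives a number 2 percentage points lower from compound 1 to compound 4 (within the scatter), and this step can be set beside the earlier one on the other core: the same change on two cores in this assay, a number 5 percentage points lower (within the scatter) from compound 2 to compound 3 and a number 2 percentage points lower (within the scatter) from compound 1 to compound 4, 3 percentage points apart, within the scatter of two such steps. Within this read-out, then, no difference appears between the two cores in what the change does. This does not show that the change carries over in any stronger sense or that it is without effect, since neither step stands clear of the scatter and a percentage at one concentration is no potency, so all that is established is that the two small steps cannot be told apart.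

Open, on these data alone, is whether another group at this place, such as an amine or an amide, would give a number clear of the narrow band held by these four compounds. Also open, as far as these compounds go, is how the same change would behave on a core that gives a much larger number in this assay, where a step could be told from the scatter.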